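Isopropyl in place of chloro on the pendant ring

A few compounds are considered here, and "the series" means these few. Any claim that something is new, unique, unknown or untested is made for them only; others in the source may bear on it.

The series shares one core carrying a pendant aryl ring, and three members have been measured in an assay on cell membranes for binding affinity to 5-hydroxytryptamine receptor 7 (Rattus norvegicus); on this read-out lower numbers stand for stronger inhibition and higher numbers for weaker inhibition. Compound 1 `Cc1c(NC2=NCCN2)cccc1-c1cccc(F)c1` gives 28.2 nM. Compound 2 `Cc1c(NC2=NCCN2)cccc1-c1cccc(C(F)(F)F)c1` gives 45.7 nM. Compound 3 `Cc1c(NC2=NCCN2)cccc1-c1cccc(Cl)c1` gives 26.3 nM. The steps linking them, a 1.6-fold higher number from compound 1 to compound 2 (0.21 log units; within the scatter), a 1.1-fold lower number from compound 1 to compound 3 (0.03 log units; within the scatter) and a 1.7-fold lower number from compound 2 to compound 3 (0.24 log units; within the scatter), all lie within the scatter, so the three numbers cannot be told apart and compound 3 is not set apart from compound 1 or compound 2.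

Compound 4 `Cc1c(NC2=NCCN2)cccc1-c1cccc(C(C)C)c1` is not yet measured. It differs from compound 3 by isopropyl in place of chloro on an aromatic carbon. The step from compound 2 to compound 3, which exchanges trifluoromethyl for chloro on the same carbon, bears most directly on this change and stayed within the scatter; the step from compound 1 to compound 3 did likewise. Nothing in the measured set points to a step beyond the scatter in this assay, and compound 4 is expected to move by a 1.7-fold higher number from compound 3 to compound 4 (0.23 log units; within the scatter). For compound 4 the estimate in this assay is 45 nM, with a range from 18 nM to 115 nM.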

Compound 4, inhibition constant: 182 nM
For compound 4 the middle estimate is 4.0-fold (0.61 log units) below the measured one; the measured number lies above the stated range.
By their numbers in this assay, from the lowest: compounds 3, 1 and 2 (each within the scatter of the next); then compound 4.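

In this assay, this aromatic carbon, meta to a large group, now gives steps beyond the scatter: a 6.9-fold higher number from compound 3 to compound 4 (0.84 log units; beyond the scatter), a 6.5-fold higher number from compound 1 to compound 4 (0.81 log units; beyond the scatter) and a 4.0-fold higher number from compound 2 to compound 4 (0.60 log units; beyond the scatter). Among the compounds shown here, the position therefore does not accept every group alike: fluoro, chloro and trifluoromethyl cannot be told apart here, while isopropyl stands apart from all three as the only group of the four without halogen. Nothing available explains this step.

A single compound cannot show whether the weaker inhibition belongs to isopropyl alone or extends to other halogen-free groups such as methyl, methoxy or an amine. On these data alone, how a longer chain or a carboxylic acid on the same carbon would read in this assay also remains open.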